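From Bromo to Carbamoyl: An Expected Cytotoxicity Value

The compounds below may be only part of what the source reports. "The series", "measured", "known", "first", "only" and "open" are said of these compounds alone.

Of the compounds shown here, three have been measured in an ADME assay on cells (Macrophage, Mus musculus) for cytotoxicity, read by resazurin assay, with a stated time of 3 days; on this read-out lower numbers stand for stronger inhibition and higher numbers for weaker inhibition. Compound 1 `COc1ccc(O)c(C(=O)Nc2cc(C(F)(F)F)cc(C(F)(F)F)c2)c1` gives 7700 nM. Compound 3 `O=C(Nc1cccc(Br)c1)c1cc(Cl)ccc1O` gives 5700 nM in this assay; its number is the smaller of the two numbers shown, but the gap to compound 1 lies within the scatter, so the two cannot be ranked against each other. Compound 2 `COc1ccc(Cl)cc1C(=O)Nc1cc(C(F)(F)F)cc(C(F)(F)F)c1` reaches only a limit in this assay, > 60000 nM, which is the limit of > 60000 nM in this assay, at which 1 of the 3 values shown sits.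

Compound 4 `NC(=O)c1cccc(NC(=O)c2cc(Cl)ccc2O)c1` has not yet been measured. It differs from compound 3 in one place: carbamoyl in place of bromo on an aromatic carbon, meta to a large group. Among the measured compounds shown here, no measured pair shows this change, so its size cannot be read from the data. The estimate is that the number rises, with an expected step of a 2.6-fold higher number from compound 3 to compound 4 (0.42 log units; beyond the scatter) that goes beyond the scatter but stops short of the limit. Compound 4 is expected to give 15000 nM in this assay, within 5000 nM to 55000 nM.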

Compound 4, half-maximal inhibitory concentration: > 60000 nM
Compound 4: only a limit was reported; the forecaster's own chance of this, stated with the estimate: 30%; middle value at least 4.0-fold (0.60 log units) away from the limit.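

In this assay, this place on the aromatic ring, meta to a large group, proves sensitive to the group it carries: the first pair differing in one place gives an at least 10-fold higher number from compound 3 to compound 4 (1.02 log units; beyond the scatter) when carbamoyl takes the place of bromo. From the compounds shown here alone, the reading for compound 4 is a limit and not a number, so the step fixes only the smallest possible size of the change, and its full size stays unknown. Compound 4 now sits at the limit of this read-out: the limit of > 60000 nM in this assay, at which 2 of the 4 values shown sit.

The compounds shown leave open how other groups at this place would read, such as a nitrile, an amine or a carboxylic acid. Resting on a single pair, they also leave open whether carbamoyl in place of bromo would give a similar step on another core.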